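A few compounds are considered here, and "the series" means these few. Any claim that something is new, unique, unknown or untested is made for them only; others in the source may bear on it.

Measured in a functional assay on HepG2 cells (Homo sapiens) for cytotoxicity, read by MTT assay, with a stated time of 72 h; a higher number here means a weaker inhibitor, a lower number a stronger inhibitor:
compound 1 `CNC(=O)c1cc(Oc2ccc(C(=O)/C=C/c3cccc(Br)c3)cc2)ccn1`: 2870 nM
compound 2 `CNC(=O)c1cc(Oc2ccc(C(=O)/C=C/c3ccc(F)cc3)cc2)ccn1`: 12600 nM
compound 3 `CNC(=O)c1cc(Oc2ccc(/C=C/C(=O)c3ccc([N+](=O)[O-])cc3)cc2)ccn1`: 41400 nM

Compound 3 stands highest of the three, beyond the scatter from both others. Compound 4 `CNC(=O)c1cc(Oc2ccc(/C=C/C(=O)c3ccc(C)cc3)cc2)ccn1` carries methyl in place of nitro on an aromatic carbon, para to a large group: methyl in place of nitro on an aromatic carbon. Among the compounds with values here, no measured step covers this exchange. The closest, a 4.4-fold higher number from compound 1 to compound 2 (0.64 log units; beyond the scatter), swaps substituted phenyl groups in compounds whose carbonyl and double bond run in the opposite order, so it offers only a rough, modest size. In this assay a modest move is expected, an estimated 2.3-fold lower number from compound 3 to compound 4 (0.36 log units; beyond the scatter), though the direction is weakly supported. For compound 4 the estimated value is 18000 nM, with an expected range of 6000 nM to 50000 nM.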

Compound 4, half-maximal inhibitory concentration: > 50000 nM
Compound 4 was reported as a limit (the forecaster's own chance of this, stated with the estimate: 8%); at least 2.7-fold (0.44 log units) between middle value and limit.
By their numbers in this assay, from the lowest: compound 1; then compound 2; then compound 3. At a limit, above all of these: compound 4.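

In this assay, compound 4 is reported only as a limit, > 50000 nM. Methyl in place of nitro on the aromatic carbon para to a large group gives an at least 1.2-fold higher number from compound 3 to compound 4 (0.08 log units; that floor lies within the scatter), so this exchange does not bring the number down, although the floor fixes no size for the step. With the carbonyl and double bond in this order, neither 4-nitrophenyl nor 4-methylphenyl gives a low number in this series.

On these data alone, an amine or a carboxylic acid at this position remains open. So does the behaviour of 4-nitrophenyl and 4-methylphenyl with the carbonyl and double bond in the opposite order.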